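This account rests on a few compounds, and the source may have more. Where it says the series, first, only, none or still open, it means among the compounds named here.

Among the compounds with values here, in a functional assay on HeLa cells (Homo sapiens) for cytotoxicity, read by MTT assay, with a stated time of 72 h (on this read-out lower numbers stand for stronger inhibition and higher numbers for weaker inhibition), compound 1 `CSCC[C@H](NC1=CC(=O)C=C(C[C@]2(C)[C@@H](C)CC[C@]3(C)C(C)=CCC[C@@H]23)C1=O)C(=O)O` gives 13900 nM and holds the lower of the two numbers so far. Compound 2 `CC(C)C[C@H](NC1=CC(=O)C=C(C(C)(C)C)C1=O)C(=O)O` gives 57200 nM in the same read-out, a gap beyond the scatter. Compound 3 `CC1=CCC[C@H]2[C@](C)(CC3=CC(=O)C=C(N[C@@H](C(=O)O)C(C)C)C3=O)[C@@H](C)CC[C@]12C` is still unmeasured and shares the core of compound 1. The change sits on an amine nitrogen, where 1-carboxy-2-methylpropyl in place of 1-carboxy-3-(methylsulfanyl)propyl on an amine nitrogen is the whole difference. Within the data shown here, no measured pair shows this change on its own, so the data offer no direct guide to its size or direction. The closest reference is compound 1 at 13900 nM as the starting point for the expectation. No step beyond the scatter is expected in this assay and the estimated step is a 1.1-fold higher number from compound 1 to compound 3 (0.03 log units; within the scatter) on that reading. For compound 3 the estimated value is 15000 nM with an expected range from 6000 nM to 36000 nM in the measurement.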

Compound 3, half-maximal inhibitory concentration: 10900 nM
Compound 3: middle estimate off by 1.4-fold (0.14 log units), on the high side; measured number inside the range.
By their numbers in this assay, from the lowest: compounds 3 and 1 (each within the scatter of the next); then compound 2.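

In this assay this position on the amine nitrogen now has its first direct reading: 1-carboxy-2-methylpropyl in place of 1-carboxy-3-(methylsulfanyl)propyl gives (a 1.3-fold lower number from compound 1 to compound 3 (0.11 log units; within the scatter)). On the shared core, the sulfur of the leaving chain is therefore not required to keep the number at this level, and the two side chains cannot be told apart in this read-out. Nothing available explains this result.

Both chains shown are open-chain and keep the carboxylic acid, so it remains open whether a methyl ester or a primary amide in its place, or a phenyl ring on the chain, would move the number beyond the scatter. From the compounds shown here alone, whether this change keeps its size on a different core also remains open.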